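Replacing the 2-hydroxyphenyl group: notes on a small series

A few compounds are considered here, and "the series" means these few. Any claim that something is new, unique, unknown or untested is made for them only; others in the source may bear on it.

In a functional assay on MGC-803 cells (Homo sapiens) for antiproliferative activity, read by CellTiter-Glo, with a stated time of 72 h (on this read-out lower numbers stand for stronger inhibition and higher numbers for weaker inhibition), compound 1 (`O=C(NO)c1ccc(/C=C/c2ccnc(-c3ccccc3O)c2)cc1`) gives 1420 nM as the lowest of three numbers. Compound 2 (`COc1ccccc1-c1cc(/C=C/c2ccc(C(=O)NO)cc2)ccn1`) gives 6350 nM and compound 3 (`COc1ccc(-c2cc(/C=C/c3ccc(C(=O)NO)cc3)ccn2)cc1`) gives 3510 nM on the same read-out. Compound 4 (`Cc1ccc(-c2cc(/C=C/c3ccc(C(=O)NO)cc3)ccn2)c(F)c1`) has not been measured. It carries 2-fluoro-4-methylphenyl in place of 2-hydroxyphenyl on an aromatic carbon, next to the ring nitrogen (2-fluoro-4-methylphenyl in place of 2-hydroxyphenyl on an aromatic carbon).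

Two measured steps also lose the hydroxy group of compound 1. Methyl in place of the hydrogen on that oxygen gives a 4.5-fold higher number from compound 1 to compound 2 (0.65 log units; beyond the scatter) and the change to 4-methoxyphenyl gives a 2.5-fold higher number from compound 1 to compound 3 (0.39 log units; beyond the scatter) in the same direction, while a 1.8-fold lower number from compound 2 to compound 3 (0.26 log units; within the scatter) stays within the scatter. Among the compounds with values here, no measured compound carries the fluoro or the ring methyl group, so this reading is only an analogy. The expected change in this assay is a modest rise of similar size, a 2.5-fold higher number from compound 1 to compound 4 (0.39 log units; beyond the scatter) as the estimated step. Compound 4 is estimated at 3500 nM (expected range 1500 nM to 8000 nM).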

Compound 4, half-maximal inhibitory concentration: 770 nM
Compound 4: middle estimate off by 4.5-fold (0.66 log units), on the high side; measured number below the stated range.
By their numbers in this assay, from the lowest: compounds 4 and 1 (each within the scatter of the next); then compounds 3 and 2 (each within the scatter of the next).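

In this assay, a hydrogen-bond donor on this aryl group is not required: 2-fluoro-4-methylphenyl has 0 hydrogen-bond donors, yet the step stays within the scatter (a 1.8-fold lower number from compound 1 to compound 4 (0.27 log units; within the scatter)). Losing the hydroxy group therefore does not by itself account for the higher numbers of the two methoxyphenyl compounds, since the new group also sits clearly apart from both (a 4.6-fold lower number from compound 3 to compound 4 (0.66 log units; beyond the scatter); an 8.2-fold lower number from compound 2 to compound 4 (0.92 log units; beyond the scatter)). Nothing available explains why these aryl groups differ.

From the compounds shown here alone, the fluoro and the ring methyl enter together, so their separate shares stay open, and 2-fluorophenyl and 4-methylphenyl compounds would be needed to divide them. Also open, going by these compounds, is how an aryl group carrying an amine or a carboxylic acid would behave at this position.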